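Aryl replacement on the shared core: outlook for compound 4

The compounds below may be only part of what the source reports. "The series", "measured", "known", "first", "only" and "open" are said of these compounds alone.

Three compounds of the series have numbers in a functional assay on BJAB cells (Homo sapiens) for antiproliferative activity, with a stated time of 4 days; a lower number here means that less compound is needed, a higher number that more compound is needed for the effect. Compound 1 `Cc1ccccc1-c1c(C)nn(-c2nc(-c3ccc(Cl)c(Cl)c3)c(SC(C)C)s2)c1C(=O)O` gives 5500 nM. Compound 2 `COc1ccccc1-c1c(C)nn(-c2nc(-c3ccc(Cl)c(Cl)c3)c(SC(C)C)s2)c1C(=O)O` gives 14700 nM. Going by the values given here, compound 3 `Cc1nn(-c2nc(-c3ccc(Cl)c(Cl)c3)c(SC(C)C)s2)c(C(=O)O)c1-c1cc(C#N)cc(C(F)(F)F)c1` gives 3600 nM, the lowest of the three numbers, although the step of a 1.5-fold lower number from compound 1 to compound 3 (0.18 log units; within the scatter) lies within the scatter and only the step of a 4.1-fold lower number from compound 2 to compound 3 (0.61 log units; beyond the scatter) stands beyond it. Within the aryl group itself, the step of a 2.7-fold higher number from compound 1 to compound 2 (0.43 log units; beyond the scatter) is also modest.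

Compound 4 `Cc1nn(-c2nc(-c3ccc(Cl)c(Cl)c3)c(SC(C)C)s2)c(C(=O)O)c1-c1cccnc1` is not yet measured. It differs from compound 3 in one place: pyridin-3-yl in place of 3-cyano-5-(trifluoromethyl)phenyl on an aromatic carbon. Among the compounds with values here, the steps that bear on this are the two aryl exchanges already seen, which moved the number by a modest amount or not at all beyond the scatter. Within the data shown here, no measured step brings a ring with a hetero atom into this place, so the direction is uncertain. Among the measured compounds shown here, compound 3 holds the lowest number so far, and a drift back toward the middle of the series is taken as the most likely outcome. Compound 4 is therefore estimated at 7000 nM, with a range from 2500 nM to 20000 nM. The expected step in this assay is a 1.9-fold higher number from compound 3 to compound 4 (0.29 log units; within the scatter), a small rise that may or may not clear the scatter.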

Compound 4, half-maximal effective concentration: 12000 nM
Beside the measured number, compound 4's estimate is 1.7-fold (0.23 log units) below it; low and high end bracket the measured number.
By their numbers in this assay, from the lowest: compounds 3 and 1 (each within the scatter of the next); then compounds 4 and 2 (each within the scatter of the next).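

Pyridin-3-yl brings the first ring with a hetero atom onto this aromatic carbon, and in this assay the exchange gives a 3.3-fold higher number from compound 3 to compound 4 (0.52 log units; beyond the scatter), a modest loss that leaves 3-cyano-5-(trifluoromethyl)phenyl, with 12 heavy atoms against 6, at the low end of the series. The same ring also gives a 2.2-fold higher number from compound 1 to compound 4 (0.34 log units; beyond the scatter), again beyond the scatter, whereas a 1.2-fold lower number from compound 2 to compound 4 (0.09 log units; within the scatter) stays within it, so pyridin-3-yl and 2-methoxyphenyl cannot be separated here and this position tolerates a ring with a hetero atom only at the high end of the numbers seen so far. Nothing on hand accounts for these differences.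

Going by these compounds, the step from compound 3 to compound 4 removes the nitrile and the trifluoromethyl and adds the ring nitrogen in a single exchange, so the share of each remains open. A plain phenyl, a pyridin-4-yl, or a pyridin-3-yl carrying a nitrile or an amine at this position would be needed to separate these contributions on the shared core.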